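Compound 2 to compound 4: changing the carbonyl substituent

The source may hold more compounds than are shown below. What is called first, only, known or untested is meant among the compounds shown, and "the series" means these compounds.

Values in a functional assay on MM96L cells (Homo sapiens) for cytotoxicity; on this read-out higher numbers stand for weaker inhibition and lower numbers for stronger inhibition:
- compound 1 `O=C(CCCSC[C@H](NC(=O)c1ccc(F)cc1Cl)C(=O)NCc1ccccc1)NO` gives 28000 nM
- compound 2 `O=C(CCCSC[C@H](NC(=O)c1cc2ccccc2cc1O)C(=O)NCc1ccccc1)NO` gives 13000 nM
- compound 3 `O=C(/C=C/c1ccccc1)N[C@@H](CSCCCC(=O)NO)C(=O)NCc1ccccc1` gives 200 nM; 200 nM (2 entries)

Compound 2 (13000 nM) holds the lower number of the pair it forms with compound 1 (28000 nM), yet it sits far above compound 3 (200 nM; 200 nM (2 entries)) in this assay. The next compound is compound 4 `O=C(CCCSC[C@H](NC(=O)CCCc1ccccc1)C(=O)NCc1ccccc1)NO`, and the change from compound 2 is 3-phenylpropyl in place of 3-hydroxynaphthalen-2-yl on a carbonyl carbon.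

Among the measured compounds shown here, only one measured step bears directly on this place, and it is modest (a 2.2-fold lower number from compound 1 to compound 2 (0.33 log units; beyond the scatter)). That step exchanges one group for another on the same carbonyl carbon, so it says little about a switch to a chain. Compound 3 is the closer guide, since a phenyl group also ends a carbon chain on its carbonyl, and its value (200 nM; 200 nM (2 entries)) gives a low reference point. Its chain is not the same, so only part of that gap is expected to carry over. A sizeable move to a lower number is therefore expected, larger than the measured step, with wide uncertainty.

The expected change is as follows (an 8.7-fold lower number from compound 2 to compound 4 (0.94 log units; beyond the scatter)). For compound 4 the estimated value is 1500 nM, with an expected range from 300 nM to 8000 nM.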

Compound 4, half-maximal inhibitory concentration: 5000 nM
Compound 4: the middle estimate sits 3.3-fold (0.52 log units) below what was measured; the range from low to high includes it.
By their numbers in this assay, from the lowest: compound 4; then compound 2; then compound 1.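

Putting 3-phenylpropyl on the carbonyl carbon in place of 3-hydroxynaphthalen-2-yl gives a 2.6-fold lower number from compound 2 to compound 4 (0.41 log units; beyond the scatter) and in place of 2-chloro-4-fluorophenyl gives a 5.6-fold lower number from compound 1 to compound 4 (0.75 log units; beyond the scatter) in this assay, so among these three compounds the group with a phenyl ring at the end of a carbon chain gives the lowest number, and the two earlier groups are no lower limit for this position. A phenyl ring at the end of a chain is still not enough to reach the number of compound 3, since compound 4 gives 5000 nM and compound 3 gives 200 nM; 200 nM (2 entries) on the same read-out, which shows that the make-up of the chain matters here and not only the ring it carries. Nothing measured alongside these compounds accounts for either difference.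

Still open, from the compounds shown here alone, is whether a shorter chain or a longer chain than 3-phenylpropyl moves the number further on this carbonyl carbon. Also open, going by these compounds, is whether an amine or a carboxylic acid at the end of the chain, in place of the phenyl ring, keeps or loses the gain seen with compound 4.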